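The source may hold more compounds than are shown below. What is called first, only, known or untested is meant among the compounds shown, and "the series" means these compounds.

In an assay on HEK293 cells for inhibition of transient receptor potential cation channel subfamily V member 1 (Homo sapiens) (a higher number here means a weaker inhibitor, a lower number a stronger inhibitor), the measured compounds stand as follows:
compound 1 `CCCCCCCCC(=O)NCc1cc(OC)c(O)cc1Br` — 16.1 nM
compound 2 `C#Cc1cc(CNC(=O)CCCCCCCC)cc(OC)c1O` — 2740 nM
compound 3 `CCCCCCCCC(=O)NCc1cc(CC)c(O)c(OC)c1` — 355 nM

Compound 1 gives the lowest number of the three; compound 3 and compound 2 both sit higher, each beyond the scatter, so compound 1 is the strongest inhibitor of the set as measured.

Compound 4 `CCCCCCCCC(=O)NCc1cc(OC)c(O)cc1/C=C/C(=O)OC` differs from compound 1 in one place: 2-(methoxycarbonyl)ethenyl in place of bromo on an aromatic carbon. Within the data shown here, the only single-point step in the set, a 7.7-fold lower number from compound 2 to compound 3 (0.89 log units; beyond the scatter), concerns a different position on a different core and a different pair of groups, so it bears only loosely on this change. Among the measured compounds shown here, no measured step exchanges a halogen for a larger chain. The expectation is a modest loss, with some risk of more; compound 4 is estimated at 50 nM, within 10 nM to 300 nM, meaning an expected 3.1-fold higher number from compound 1 to compound 4 (0.49 log units; beyond the scatter).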

Compound 4, half-maximal inhibitory concentration: 3930 nM
Estimate against measurement, compound 4: 79-fold (1.90 log units) below; measured number above the stated range.
By their numbers in this assay, from the lowest: compound 1; then compound 3; then compounds 2 and 4 (each within the scatter of the next).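

In this assay, the position para to a methoxy group and meta to a hydroxy group proves highly sensitive to this exchange: 2-(methoxycarbonyl)ethenyl in place of bromo gives a 240-fold higher number from compound 1 to compound 4 (2.39 log units; beyond the scatter). The low number of compound 1 therefore does not carry over when the single bromine gives way to this larger group with its two hydrogen-bond acceptors. Nothing available accounts for the loss.

Still open, on these data alone, is which part of the new group goes with the loss: the double bond, the methyl ester or the added atoms. A chloro, a methyl or a carboxylic acid at this position would bear on that question.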